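The source may hold more compounds than are shown below. What is called first, only, known or untested is meant among the compounds shown, and "the series" means these compounds.

Working notes on the series, read in a functional assay on SW-620 cells (Homo sapiens) for cytotoxicity, read by MTT assay, with a stated time of 72 h; on this read-out lower numbers stand for stronger inhibition and higher numbers for weaker inhibition. Compound 1 `COc1ccc(/C=C2\CCC/C(=C\c3cccc(Cl)c3)C2=O)cc1OC` gives 5100 nM. Compound 2 `COc1ccc(/C=C2\CCC/C(=C\c3ccccc3Br)C2=O)cc1OC` gives 5300 nM. Compound 3 `COc1ccc(/C=C2\CCC/C(=C\c3cccc(Br)c3)C2=O)cc1OC` gives 4200 nM and stands within the scatter of both other compounds, with a 1.2-fold lower number from compound 1 to compound 3 (0.08 log units; within the scatter) and a 1.3-fold lower number from compound 2 to compound 3 (0.10 log units; within the scatter) as its steps.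

Compound 4 `COc1ccccc1/C=C1\CCC/C(=C\c2ccc(OC)c(OC)c2)C1=O` differs from compound 3 in one place: 2-methoxyphenyl in place of 3-bromophenyl on a double-bonded chain carbon bound to a double-bonded ring carbon. This is 2-methoxyphenyl in place of 3-bromophenyl on a double-bonded chain carbon bound to a double-bonded ring carbon.

The measured steps that bear on this change are the swaps at that same place, namely a 1.0-fold higher number from compound 1 to compound 2 (0.02 log units; within the scatter) and a 1.3-fold lower number from compound 2 to compound 3 (0.10 log units; within the scatter). Both are small and lie within the scatter. Within the data shown here, none of the measured compounds carries 2-methoxyphenyl, so the data contain no direct comparison for this group, and the range has to stay wide.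

The anchor is compound 3 at 4200 nM, and no move beyond the scatter is expected in this assay. The expected step is a 1.1-fold higher number from compound 3 to compound 4 (0.03 log units; within the scatter). For compound 4 the estimated value is 4500 nM, with an expected range from 1800 nM to 11000 nM.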

Compound 4, half-maximal inhibitory concentration: 7800 nM
Compound 4: the middle estimate sits 1.7-fold (0.24 log units) below what was measured; measured number inside the range.
By their numbers in this assay, from the lowest: compounds 3, 1, 2 and 4 (each within the scatter of the next).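

Among these compounds, at this place, on a double-bonded chain carbon bound to a double-bonded ring carbon, 2-methoxyphenyl is the first group without a halogen, and it brings one hydrogen-bond acceptor where 3-bromophenyl has none; this assay gives a 1.9-fold higher number from compound 3 to compound 4 (0.27 log units; within the scatter), the widest step so far but one that does not separate the two compounds. The other two comparisons agree, with a 1.5-fold higher number from compound 2 to compound 4 (0.17 log units; within the scatter) and a 1.5-fold higher number from compound 1 to compound 4 (0.18 log units; within the scatter), so a methoxy-bearing phenyl at this place stays within the scatter of all three halogen-bearing compounds, and the four compounds remain unseparated in this read-out. No available evidence bears on why these values fall as they do.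

The compounds shown leave open whether any group at this place can move the read-out beyond the scatter, as all the groups so far are phenyl rings carrying a single halogen or methoxy group. An amine or a carboxylic acid on that phenyl ring, or a longer chain in place of the methoxy group, would test this.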